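A fluoro for a chloro on a benzoxazole sulfonamide

This account rests on a few compounds, and the source may have more. Where it says the series, first, only, none or still open, it means among the compounds named here.

In an assay on cells for inhibition of HSP60/HSP10 (Homo sapiens), with a stated time of 60 min (on this read-out higher numbers stand for weaker inhibition and lower numbers for stronger inhibition), compound 2 `O=S(=O)(Nc1ccc(-c2nc3ccccc3o2)cc1)c1ccc(Cl)c(C(F)(F)F)c1` gives 12000 nM and compound 1 `O=S(=O)(Nc1ccc2oc(-c3ccc(NS(=O)(=O)c4cccc5nonc45)cc3)nc2c1)c1ccc(Cl)s1` gives 13000 nM, a gap that sits within the usual scatter, so neither can be called the stronger. Compound 3 `Cc1ccccc1S(=O)(=O)Nc1ccc2oc(-c3ccccc3)nc2c1` reaches only > 100000 nM, which is a limit of this assay and not a number, in line with the limit of > 100000 nM in this assay, at which 1 of the 3 values shown sits. Compound 4 `O=S(=O)(Nc1ccc(-c2nc3ccccc3o2)cc1)c1ccc(F)c(C(F)(F)F)c1` differs from compound 2 by fluoro in place of chloro on an aromatic carbon. Among the measured compounds shown here, no measured pair shows this exchange, so the expected step is small and could run either way, most likely staying within the scatter. On that basis compound 4 is estimated at 18000 nM, between 7000 nM and 45000 nM, which is expected to mean a step of a 1.5-fold higher number from compound 2 to compound 4 (0.18 log units; within the scatter).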

Compound 4, half-maximal inhibitory concentration: 28000 nM
Compound 4: the middle estimate sits 1.6-fold (0.19 log units) below what was measured; low and high end bracket the measured number.
By their numbers in this assay, from the lowest: compounds 2 and 1 (each within the scatter of the next); then compound 4. At a limit, above all of these: compound 3.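

Exchanging chloro for fluoro at this position, ortho to a trifluoromethyl group, is not a neutral swap: it gives a 2.3-fold higher number from compound 2 to compound 4 (0.37 log units; beyond the scatter) in this assay and so modestly weakens inhibition. Among the compounds shown here, this is the first pair in the set that differs in one place only, and here chloro gives the stronger inhibition of the two halogens. Going by these compounds, whether a methyl group, a methoxy group or a plain hydrogen at this position would do better or worse stays open, as does whether the exchange acts the same way on another core. Nothing among the data shown explains the size of this step.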